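Estimating an Ethoxyphenyl Analogue from Three Measured Compounds

This account rests on a few compounds, and the source may have more. Where it says the series, first, only, none or still open, it means among the compounds named here.

Measured so far:
- compound 1, `COc1ccccc1Nc1nc(SCc2ccc(C(F)(F)F)cc2)nc2ccccc12`, gives > 50000 nM in a functional assay on MGC-803 cells (Homo sapiens) for cytotoxicity, read by MTT assay, with a stated time of 72 h; on this read-out higher numbers stand for weaker inhibition and lower numbers for stronger inhibition; this is a limit of the assay, not a number.
- compound 2, `Cc1ccccc1Nc1nc(SCc2ccc(C(F)(F)F)cc2)nc2ccccc12`, gives 24400 nM in this assay.
- compound 3, `FC(F)(F)c1ccc(CSc2nc(Nc3ccc(Cl)cc3)c3ccccc3n2)cc1`, gives 16800 nM in this assay.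

Compound 1 stands at the weak end of what has been measured: it sits at the limit of > 50000 nM in this assay, at which 1 of the 3 values shown sits, so only a bound is known for it, and every step that starts from it is a bound as well. The step of an at least 2.0-fold lower number from compound 1 to compound 2 (0.31 log units; beyond the scatter) and the step of an at least 2.9-fold lower number from compound 1 to compound 3 (0.47 log units; beyond the scatter) both lower the number, each beyond the scatter. The step of a 1.5-fold lower number from compound 2 to compound 3 (0.16 log units; within the scatter) lies within the scatter, so compound 2 and compound 3 cannot be ordered.

Compound 4, `CCOc1ccc(Nc2nc(SCc3ccc(C(F)(F)F)cc3)nc3ccccc23)cc1`, differs from compound 1 in one place: 4-ethoxyphenyl in place of 2-methoxyphenyl on a nitrogen on an aromatic ring. The two measured steps from compound 1 bear on this change, since each also replaces or alters the 2-methoxyphenyl group, and each gave a modest lowering from the limit. Within the data shown here, a similar modest lowering is expected here, although the 4-ethoxyphenyl group itself has no measured precedent, so the possibility that compound 4 also returns only a limit cannot be ruled out. The expected step is an at least 2.2-fold lower number from compound 1 to compound 4 (0.35 log units; beyond the scatter). For compound 4 the estimate is 22000 nM, with a range from 8000 nM to 60000 nM.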

Compound 4, half-maximal inhibitory concentration: 37000 nM
The estimate for compound 4 lay 1.7-fold (0.23 log units) below the measured number; low and high end bracket the measured number.
By their numbers in this assay, from the lowest: compounds 3, 2 and 4 (each within the scatter of the next, the first and the last beyond it). At a limit, above all of these: compound 1.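

Replacing the 2-methoxyphenyl group with 4-ethoxyphenyl on this nitrogen gives a number rather than a limit in this assay, but the change is only bounded and its floor does not clear the scatter: an at least 1.3-fold lower number from compound 1 to compound 4 (0.13 log units; that floor lies within the scatter) is all that can be said. Swapping chloro for ethoxy on the aromatic carbon gives a 2.2-fold higher number from compound 3 to compound 4 (0.34 log units; beyond the scatter), the first step between two exact numbers to lie beyond the scatter, so the group on this ring can shift the reading even in this narrow range, whereas a 1.5-fold higher number from compound 2 to compound 4 (0.18 log units; within the scatter) leaves compound 2 and compound 4 unordered. Going by these compounds, the reading for compound 1 remains a limit of the assay, so the true size of its step stays unknown: the limit of > 50000 nM in this assay, at which 1 of the 4 values shown sits.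

The change from compound 1 to compound 4 alters both the length of the chain and where it sits on the ring, and the compounds shown cannot separate these two effects. They also leave open how this position would respond to a chain longer than ethoxy, or to an amine or a carboxylic acid on the ring.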